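Furan for phenyl on the ester carbonyl

The source may hold more compounds than are shown below. What is called first, only, known or untested is meant among the compounds shown, and "the series" means these compounds.

Compound 1 `O=C(OC1CCC(CN2CCN(c3cc(=O)c4cc(C(F)(F)F)cc([N+](=O)[O-])c4s3)CC2)CC1)c1ccccc1` is the starting point of this account. Among the compounds with values here, in an ADME assay on cells (Hepatocyte, Homo sapiens) for metabolic stability (a higher number here means that the compound lasts longer, a lower number that the compound disappears faster), compound 1 gives 0.603 h, and this is the only actual number in the set. Compound 2 `O=c1cc(N2CCN(CC3CCC(NS(=O)(=O)c4ccccc4)CC3)CC2)sc2c([N+](=O)[O-])cc(C(F)(F)F)cc12` was run in the same assay. In this assay compound 2 reaches > 1.55 h, which is a limit of the assay rather than a number. Within the data shown here, the one measured step, an at least 2.5-fold higher number from compound 1 to compound 2 (0.41 log units; beyond the scatter), runs up against that limit of > 1.55 h in this assay, at which 1 of the 2 values shown sits, and concerns a different part of the molecule than the step followed here.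

Compound 3 `O=C(OC1CCC(CN2CCN(c3cc(=O)c4cc(C(F)(F)F)cc([N+](=O)[O-])c4s3)CC2)CC1)c1ccco1` has not yet been measured. It differs from compound 1 as follows: furan-2-yl in place of phenyl on a carbonyl carbon. Among the measured compounds shown here, no measured pair in this set changes the aromatic ring on the carbonyl carbon, so the step from compound 1 to compound 2 gives no direct guide to this change. For the measured compounds named here, with no comparable step to lean on, the change is expected to stay within the scatter. Compound 3 is therefore estimated at 0.6 h, with a range from 0.3 h to 1.3 h. That estimate means an expected step of a 1.0-fold lower number from compound 1 to compound 3 (0.00 log units; within the scatter), within the scatter of the assay.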

Compound 3, half-life: 0.075 h
Compound 3: middle estimate off by 8.0-fold (0.90 log units), on the high side; the measured number lies below the stated range.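

In this assay, the aromatic ring on the carbonyl carbon proves to be a sensitive position, even though the replacement is small: furan-2-yl in place of phenyl gives an 8.0-fold lower number from compound 1 to compound 3 (0.91 log units; beyond the scatter). The wider comparison at the saturated ring carbon, with ((furan-2-yl)carbonyl)oxy in place of (phenylsulfonyl)amino, gives an at least 20-fold lower number from compound 2 to compound 3 (1.31 log units; beyond the scatter), so the two changes measured at this ring carbon now span a much wider range than the first step showed. Compound 2 gives > 1.55 h, which is a limit of the assay and not a number, so this larger step can be read only as a minimum: the limit of > 1.55 h in this assay, at which 1 of the 3 values shown sits.

The compounds shown leave open whether the loss belongs to furan-2-yl in particular or would also appear with thiophen-2-yl, pyridin-3-yl or cyclohexyl on the same carbonyl carbon. They also leave open whether furan-2-yl would have a similar effect in an amide, with nitrogen in place of the oxygen next to the carbonyl group, or on the sulfonyl group of compound 2.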